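Cyanoguanidine series: azidonitrophenyl to tosyl on the amine

This account rests on a few compounds, and the source may have more. Where it says the series, first, only, none or still open, it means among the compounds named here.

Compound 1 `N#CN/C(=N\CCNc1ccc(N=[N+]=[N-])cc1[N+](=O)[O-])NCCCOc1cccc(CN2CCCCC2)c1` is followed in a functional assay on cardiac atrium for antagonist activity at histamine H2 receptor (Cavia porcellus) (on this read-out higher numbers stand for higher potency (the scale is a negative logarithm) and lower numbers for lower potency), where compound 1 gives 7.39. Compound 2 `Nc1ccc(C(=O)NCCNC(=O)NCCCOc2cccc(CN3CCCCC3)c2)cc1` in this assay gives 7.23, a value within the usual scatter of that of compound 1; no order between the two can be read from these numbers. Compound 3 `Cc1ccc(S(=O)(=O)NCC/N=C(\NC#N)NCCCOc2cccc(CN3CCCCC3)c2)cc1` differs from compound 1 in one place: (4-methylphenyl)sulfonyl in place of 4-azido-2-nitrophenyl on an amine nitrogen. With no measured step of this kind among the two compounds shown, only a small step, downward if any, is expected for this assay, of a size that may not exceed the scatter: a number 0.39 log units lower from compound 1 to compound 3 (beyond the scatter). Compound 3 is expected to give 7, within 6.3 to 7.7.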

Compound 3, negative logarithm of the antagonist equilibrium constant: 6.13
Estimate against measurement, compound 3: 0.87 log units above; measured number outside the range, below it.
By their numbers in this assay, from the lowest: compound 3; then compounds 2 and 1 (each within the scatter of the next).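

On the amine nitrogen whose other neighbour is a saturated chain carbon, the substituent is not interchangeable in this assay: (4-methylphenyl)sulfonyl in place of 4-azido-2-nitrophenyl gives a number 1.26 log units lower from compound 1 to compound 3 (beyond the scatter) even though both groups hold one six-membered aromatic ring of carbon only. Going by these compounds alone, this is the first measured step at this position, and it is large. Nothing measured here accounts for its size. From the compounds shown here alone, it remains open whether the drop goes with the sulfonyl link or with the ring substituents, and how a benzoyl or methanesulfonyl group on the same nitrogen would read.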